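Changing the Group on a Sulfonamide Nitrogen

The source may hold more compounds than are shown below. What is called first, only, known or untested is meant among the compounds shown, and "the series" means these compounds.

In a functional assay on cells (leukaemia cell line, Homo sapiens) for inhibition, read by sulforhodamine B assay, with a stated time of 48 h (on this read-out higher numbers stand for weaker inhibition of growth and lower numbers for stronger inhibition of growth), compound 3 (`COc1cc(NS(=O)(=O)c2ccc(-c3cnc(C4CC4)o3)cc2)ccc1F`) gives 328 nM and stands level with compound 2 (`O=S(=O)(Nc1ccccc1Cl)c1ccc(-c2cnc(C3CC3)o2)cc1`) at 429 nM and compound 1 (`O=S(=O)(Nc1ccc(Cl)cc1Cl)c1ccc(-c2cnc(C3CC3)o2)cc1`) at 481 nM on this small set. All three share one core and differ only in the group on the sulfonamide nitrogen.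

Compound 4 (`Cc1cc(Cl)ccc1NS(=O)(=O)c1ccc(-c2cnc(C3CC3)o2)cc1`) keeps that core and carries 4-chloro-2-methylphenyl in place of 4-fluoro-3-methoxyphenyl on a sulfonamide nitrogen.

The measured steps that bear on this concern the same group. They are a 1.3-fold lower number from compound 2 to compound 3 (0.12 log units; within the scatter) and a 1.5-fold lower number from compound 1 to compound 3 (0.17 log units; within the scatter) and also a 1.1-fold lower number from compound 1 to compound 2 (0.05 log units; within the scatter) for hydrogen in place of chloro. Each lies within the scatter, so no clear step is expected in this assay here, though three compounds are a thin basis. The estimate means a 1.3-fold higher number from compound 3 to compound 4 (0.11 log units; within the scatter) and this expected step is no real separation. For compound 4 the estimated value is 420 nM (expected range 230 nM to 760 nM).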

Compound 4, concentration for 50% growth inhibition: 277 nM
For compound 4 the middle estimate is 1.5-fold (0.18 log units) above the measured one; the range from low to high includes it.
By their numbers in this assay, from the lowest: compounds 4, 3, 2 and 1 (each within the scatter of the next).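

In this assay, 4-chloro-2-methylphenyl on the sulfonamide nitrogen gives a 1.2-fold lower number from compound 3 to compound 4 (0.07 log units; within the scatter), and the comparisons with the two chlorinated compounds give a 1.5-fold lower number from compound 2 to compound 4 (0.19 log units; within the scatter) and a 1.7-fold lower number from compound 1 to compound 4 (0.24 log units; within the scatter). So a fourth group, this one carrying a methyl, still leaves the number within the scatter of all three earlier compounds, and the flat picture at this position now covers a wider set of substituted phenyl groups. Nothing shown offers an explanation for this flatness.

On these data alone, all four groups here are substituted phenyl rings, so it remains open whether the number would hold with a cyclohexyl group on this nitrogen, or with a phenyl ring bearing an amine or a carboxylic acid. As far as these compounds go, whether changes elsewhere on the shared core would move the number further also remains open.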